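Swapping a methyl for hydrogen on the long-chain compound

The source may hold more compounds than are shown below. What is called first, only, known or untested is meant among the compounds shown, and "the series" means these compounds.

Measured in a functional assay on HCT-116 cells (Homo sapiens) for antiproliferative activity, read by MTT assay, with a stated time of 48 h; a higher number here means a weaker inhibitor, a lower number a stronger inhibitor:
Compound 1 `CCCCC(CCO)n1cnc2c(N)ncnc21`: > 50000 nM
Compound 2 `CCCCCCCC(CCO)n1cnc2c(NC)ncnc21`: 12500 nM

The value of compound 1 is a limit of the assay, not a number. For the measured compounds named here, that leaves compound 2, at 12500 nM, with the only true number in this assay.

Compound 3 `CCCCCCCC(CCO)n1cnc2c(N)ncnc21` differs from compound 2 in one place: hydrogen in place of methyl on a nitrogen on an aromatic ring. Going by the values given here, no measured pair shows this change on its own, so the expected 1.0-fold lower number from compound 2 to compound 3 (0.02 log units; within the scatter) is none beyond the usual scatter, in either direction. The estimate for compound 3 is 12000 nM, with an expected range of 5000 nM to 30000 nM.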

Compound 3, half-maximal inhibitory concentration: > 50000 nM
Compound 3: no number, only a limit (the forecaster's own chance of this, stated with the estimate: 10%); at least 4.1-fold (0.61 log units) between middle value and limit.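

In this assay, for the compounds shown here, replacing the methyl on this aromatic-ring nitrogen with hydrogen gives an at least 4.0-fold higher number from compound 2 to compound 3 (0.60 log units; beyond the scatter), the first readable step and one that lies beyond the scatter. As far as these compounds go, the true size of this step stays unknown, because the value of compound 3 is only a limit: the limit of > 50000 nM in this assay, at which 2 of the 3 values shown sit. The step from compound 1 to compound 3 cannot be read, since both values are limits. From the compounds shown here alone, what an ethyl or a cyclopropyl on this nitrogen would give remains open, as does the effect of the methyl on the shorter chain of compound 1.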